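Swapping dimethylamino for acetyl on the aryl amide

The compounds below may be only part of what the source reports. "The series", "measured", "known", "first", "only" and "open" are said of these compounds alone.

Compound 1, `CC(=O)Nc1ccc(NC(=O)c2cn(Cc3c(F)cccc3F)c3ccc(=O)[nH]c3c2=O)cc1`, in an in vitro assay on Sf21 cells for inhibition of high affinity 3',5'-cyclic-AMP phosphodiesterase 7A (Homo sapiens), read by scintillation proximity assay, with a stated time of 30 min (a lower number here means a stronger inhibitor, a higher number a weaker inhibitor), gives 24 nM. Compound 2, `O=C(NCc1ccncc1)c1ccc(NC(=O)c2cn(Cc3c(F)cccc3F)c3ccc(=O)[nH]c3c2=O)cc1`, in this assay gives 20 nM. Compound 3, `CN(C)c1ccc(NC(=O)c2cn(Cc3c(F)cccc3Cl)c3ccc(=O)[nH]c3c2=O)cc1`, in this assay gives 39 nM.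

Compound 3 has the highest number of the three, yet its gaps to compound 1 and compound 2 both fall within the scatter, so no order among them can be claimed. Compound 4, `CC(=O)c1ccc(NC(=O)c2cn(Cc3c(F)cccc3Cl)c3ccc(=O)[nH]c3c2=O)cc1`, differs from compound 3 by acetyl in place of dimethylamino on an aromatic carbon. Going by the values given here, the only measured step at that place of the ring, a 1.2-fold lower number from compound 1 to compound 2 (0.08 log units; within the scatter), was within the scatter. The step from compound 3 to compound 4 is therefore expected to be a 1.1-fold lower number from compound 3 to compound 4 (0.05 log units; within the scatter), in no clear direction. Compound 4 is estimated in this assay at 35 nM, with a range from 12 nM to 100 nM.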

Compound 4, half-maximal inhibitory concentration: 18 nM
For compound 4 the middle estimate is 1.9-fold (0.29 log units) above the measured one; measured number inside the range.
By their numbers in this assay, from the lowest: compounds 4, 2, 1 and 3 (each within the scatter of the next, the first and the last beyond it).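

In this assay, acetyl in place of dimethylamino gives a 2.2-fold lower number from compound 3 to compound 4 (0.34 log units; beyond the scatter), a modest step but the first at this aromatic carbon, para to a large group, to lie beyond the scatter. The earlier step, a 1.2-fold lower number from compound 1 to compound 2 (0.08 log units; within the scatter), did not show this, whereas here two groups of 3 heavy atoms each are enough to separate the numbers. No measurement available bears on why the number falls. As far as these compounds go, whether a carboxylic acid or a longer chain such as propionyl at this place would follow acetyl stays open, as does whether the same swap would give a similar step on the core of compound 1.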